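This account rests on a few compounds, and the source may have more. Where it says the series, first, only, none or still open, it means among the compounds named here.

Three analogues sharing one core have been measured in a functional assay on MCF7 cells (Homo sapiens) for antiproliferative activity, read by CCK-8 assay, with a stated time of 72 h; on this read-out higher numbers stand for weaker inhibition and lower numbers for stronger inhibition. Compound 1 `COc1cc(C(=O)Nc2ccc(C(=O)/C=C/c3nc(C)c(C)nc3C)cc2)cc(OC)c1OC` gives 2760 nM; compound 2 `Cc1nc(C)c(/C=C/C(=O)c2ccc(NC(=O)c3ccc(F)cc3F)cc2)nc1C` gives 1610 nM; compound 3 `COc1ccc(C(=O)Nc2ccc(C(=O)/C=C/c3nc(C)c(C)nc3C)cc2)cc1` gives 1410 nM. Compound 2 thus stands second highest of the three, with compound 3 nearest and compound 1 furthest, both within the scatter. The step toward compound 4 `COc1cccc(OC)c1C(=O)Nc1ccc(C(=O)/C=C/c2nc(C)c(C)nc2C)cc1` is 2,6-dimethoxyphenyl in place of 2,4-difluorophenyl on a carbonyl carbon. Among the measured compounds shown here, one measured step bears on it, the swap on the same carbonyl carbon from compound 2 to compound 3, which gave a 1.1-fold lower number from compound 2 to compound 3 (0.06 log units; within the scatter). Compound 1 also carries methoxy groups on that phenyl, and its value and that of compound 2 lie within the scatter of each other. Compound 4 is therefore expected to shift by a 1.2-fold higher number from compound 2 to compound 4 (0.09 log units; within the scatter), not beyond the scatter. Compound 4 is estimated at 2000 nM, within 900 nM to 4500 nM.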

Compound 4, half-maximal inhibitory concentration: 2470 nM
For compound 4 the middle estimate is 1.2-fold (0.09 log units) below the measured one; the range from low to high includes it.
By their numbers in this assay, from the lowest: compounds 3, 2, 4 and 1 (each within the scatter of the next).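

Against the earlier groups, 2,6-dimethoxyphenyl on the carbonyl carbon gives a 1.5-fold higher number from compound 2 to compound 4 (0.19 log units; within the scatter) and a 1.8-fold higher number from compound 3 to compound 4 (0.24 log units; within the scatter) in this assay. Although it brings hydrogen-bond acceptors where 2,4-difluorophenyl has none, neither step leaves the scatter, so this position now holds a further substituted phenyl without a clear change. Nothing available here accounts for these small steps. The compounds shown leave open whether a different group on this carbonyl carbon, such as a saturated amine or a chain ending in a carboxylic acid, would move the number beyond the scatter.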